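The source may report more compounds than this note shows. Statements on the series, on what has been measured and on what is new or still open speak of the compounds shown alone.

Of the compounds shown here, two from this series have been measured. Compound 1 `COc1ccc(-c2nc(NN)n(C)c(=O)c2C#N)cc1` gives, in a functional assay, with a stated time of 150 min (on this read-out higher numbers stand for weaker inhibition and lower numbers for stronger inhibition), a value of 56 ug/mL. Compound 2 `CCOC(=O)c1cnn(-c2nc(-c3cccc(OC)c3OC)c(C#N)c(=O)n2C)c1N` gives in this assay a value of 69 ug/mL. On these two numbers compound 2 cannot be set apart from compound 1: the gap between them lies within the usual scatter of repeated measurements, so neither can be called stronger or weaker.

The next compound, compound 3 `CCOC(=O)c1cnn(-c2nc(-c3ccco3)c(C#N)c(=O)n2C)c1N`, has not yet been measured. It differs from compound 2 in a single place: furan-2-yl in place of 2,3-dimethoxyphenyl on an aromatic carbon. Within the data shown here, no pair of measured compounds shows a step of this kind, so there is nothing to set an expected size from. The step of a 1.0-fold higher number from compound 2 to compound 3 (0.01 log units; within the scatter) is therefore estimated as none beyond the scatter. For compound 3 the expected value in this assay is 70 ug/mL, with a range from 30 ug/mL to 160 ug/mL.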

Compound 3, half-maximal inhibitory concentration: 108 ug/mL
Compound 3: middle estimate off by 1.5-fold (0.19 log units), on the low side; the measured number falls inside the stated range.
By their numbers in this assay, from the lowest: compounds 1, 2 and 3 (each within the scatter of the next).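

Replacing 2,3-dimethoxyphenyl with furan-2-yl on this aromatic carbon, next to the ring nitrogen and ortho to the cyano group, gives in this assay a 1.6-fold higher number from compound 2 to compound 3 (0.19 log units; within the scatter) and so leaves the read-out indistinguishable. At this position, then, a five-membered aromatic ring with one hetero atom and a six-membered aromatic ring of carbon only cannot be told apart, even though the entering group has fewer heavy atoms than the one it replaces. Nothing measured here explains why the two compounds read alike.

As far as these compounds go, whether an amine, a carboxylic acid or a longer alkyl chain on this aromatic carbon would move the number beyond the scatter remains open. So does the reading for a phenyl group with no methoxy groups at all.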